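Removing the remaining fluoro from the shared core

The source may hold more compounds than are shown below. What is called first, only, known or untested is meant among the compounds shown, and "the series" means these compounds.

Compound 1 `Cc1cc(-c2nc3cc(F)c(F)cc3s2)ccc1N` and compound 2 `Cc1cc(-c2nc3ccc(F)cc3s2)ccc1N` share a core and differ by a single fluoro on an aromatic carbon. In a functional assay on OVCAR-5 cells (Homo sapiens) for inhibition (on this read-out lower numbers stand for stronger inhibition of growth and higher numbers for weaker inhibition of growth), compound 1 gives only a limit, > 100000 nM. In this assay compound 2 likewise gives only a limit, > 100000 nM. The step that the two limits leave unreadable from compound 1 to compound 2 therefore cannot be read, since both values sit at the limit of > 100000 nM in this assay, at which 2 of the 2 values shown sit. Compound 3 `Cc1cc(-c2nc3ccccc3s2)ccc1N` is not yet measured; it differs from compound 2 by hydrogen in place of fluoro on an aromatic carbon. Among the compounds with values here, the only measured step of the same kind, a step that the two limits leave unreadable from compound 1 to compound 2, bears on it but yields no size. With both measured compounds at the limit, no shift beyond the scatter in this assay can be expected in either direction, and compound 3 is expected most likely to return a limit as well. The step that the limit leaves unreadable from compound 2 to compound 3 is accordingly estimated as essentially none. For compound 3 the estimate in this assay is 150000 nM, with a range from 30000 nM to 800000 nM.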

Compound 3, concentration for 50% growth inhibition: 1900 nM
Compound 3: the middle estimate sits 79-fold (1.90 log units) above what was measured; measured number below the stated range.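

The change of fluoro to hydrogen at this position, on the six-membered aromatic ring of carbon only, gives the first readable activity in the series: in this assay it is an at least 52-fold lower number from compound 2 to compound 3 (1.72 log units; beyond the scatter). Compound 2 gives only a limit, so this size is a lower bound, and the step carries the series from no readable growth inhibition to a measurable value. The same kind of change from compound 1 to compound 2 cannot be read, because both compounds sit at one ceiling: the limit of > 100000 nM in this assay, at which 2 of the 3 values shown sit.

Open, as far as these compounds go, is whether a chloro, a methoxy or a hydroxyl at this position would read like compound 2 or like compound 3. Also open, from the compounds shown here alone, is how a single fluoro at the other aromatic carbon of compound 1 would read, which leaves unsettled whether this position or any fluoro on the ring decides the outcome.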